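Triazole anilides and hydroxamates: carboxylic acid variant of compound 2

This account rests on a few compounds, and the source may have more. Where it says the series, first, only, none or still open, it means among the compounds named here.

Measured so far in an assay on Sf9 cells for inhibition of protein deacetylase HDAC6 (Homo sapiens), read by fluorescence, with a stated time of 40 min, tested at 100 nM; on this read-out higher numbers stand for more inhibition at the one concentration tested (going by the name of the read-out) and lower numbers for less inhibition:
compound 1 `Cc1ccccc1-n1nc(-c2ccccc2)nc1CNc1ccc(C(=O)NO)cc1` gives 57.1%
compound 2 `Nc1ccccc1NC(=O)c1ccc(NCc2nc(-c3ccccc3)nn2-c2ccccc2)cc1` gives 5%
compound 3 `Cc1ccc(-c2nc(CNc3ccc(C(=O)NO)cc3)n(-c3ccccc3)n2)s1` gives 79.7%

Compound 2 stands lowest of the three numbers. Its nearest neighbour is compound 1, whose number lies higher by a gap beyond the scatter; compound 3 lies further above, also beyond the scatter. Among the compounds with values here, both compounds 1 and 3 carry a hydroxamic acid, whereas compound 2 carries the (2-aminophenyl)carbamoyl group in that position, and this is the only compound of the three without the hydroxamic acid.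

Not yet measured is compound 4 `O=C(O)c1ccc(NCc2nc(-c3ccccc3)nn2-c2ccccc2)cc1`. It differs from compound 2 at one place: hydroxy in place of (2-aminophenyl)amino on a carbonyl carbon. Within the data shown here, neither compound 2 nor compound 4 carries a hydroxamic acid, and no measured pair in the set bears on a change of this kind, so the step must be judged from the single value of compound 2 alone.

Compound 4 is expected to remain low because compound 2 gives 5% in this assay, and the expected step of no change at the digits printed from compound 2 to compound 4 (within the scatter) is none beyond the scatter. The estimate for compound 4 in this assay is 5%, within a range from -8% to 20%.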

Compound 4, a percentage reported as inhibition, at one concentration (the size of the read-out at that concentration, not a potency): -0.4%
Estimate against measurement, compound 4: 5.4 percentage points above; low and high end bracket the measured number.
By their numbers in this assay, from the lowest: compounds 4 and 2 (each within the scatter of the next); then compound 1; then compound 3.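

In this assay, hydroxy in place of (2-aminophenyl)amino on a carbonyl carbon gives a number 5.4 percentage points lower from compound 2 to compound 4 (within the scatter), so this read-out does not separate the two groups at this position. The change removes a six-membered aromatic ring of carbon only and takes the group from 8 heavy atoms to 1, yet the number does not move beyond the scatter. With compound 2 at 5% and compound 4 at -0.4%, both values lie near zero at the one concentration tested, so this pair shows that neither the (2-aminophenyl)carbamoyl group nor the carboxy group lifts the number on this core, but it cannot rank them.

The data shown offer no explanation for this result. Still open, from the compounds shown here alone, is how a hydroxamic acid, a primary amide or a methyl ester would read on the core of compound 2 at this carbonyl carbon, since compounds 1 and 3 differ from compound 2 in more than one place and so do not settle the effect of the hydroxamic acid alone.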